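The source may hold more compounds than are shown below. What is called first, only, known or untested is meant among the compounds shown, and "the series" means these compounds.

Compound 1 `CCN1CCC(NC(=O)c2nc(C(C)C)n3ccccc23)CC1` — 100%
Compound 2 `CC(C)c1nc(C(=O)NC2C3CN(CC4CCOCC4)CC32)c2ccccn12` — 19%
Compound 3 `CC(C)c1nc(C(=O)NC[C@@H]2[C@H]3CN(C4CCC4)C[C@@H]23)c2ccccn12` — 59%

Of the compounds shown here, three have so far been measured in a functional assay on CHO cells for agonist activity at 5-hydroxytryptamine receptor 4 (Homo sapiens), read by a luciferase reporter and cAMP accumulation, with a stated time of 4 h; a lower number here means a smaller maximal response, a higher number a larger maximal response. Within that set compound 3 holds the second highest largest response of the three. Its nearest neighbour is compound 2, whose largest response lies lower by a margin beyond the usual scatter; furthest away is compound 1, whose largest response lies higher by a margin that is likewise beyond the scatter. All three share the same core and the same amide link, and they differ in the group that sits on the amine nitrogen in a ring and in the ring system that carries that nitrogen.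

The next compound, compound 4 `COCC(C)(C)CN1C[C@@H]2[C@@H](CNC(=O)c3nc(C(C)C)n4ccccc34)[C@@H]2C1`, has not yet been measured in this assay. It differs from compound 3 in one place:

2-(methoxymethyl)-2-methylpropyl in place of cyclobutyl on an amine nitrogen in a ring

Among the compounds with values here, no pair of measured compounds differs in only this position, so there is no measured step to lean on. Within the data shown here, with the group on the amine nitrogen in a ring being the only change, the step from compound 3 to compound 4 is expected to be small, if anything somewhat downward, and probably within the scatter, as a number 9 percentage points lower from compound 3 to compound 4 (within the scatter) expresses. Compound 4 is therefore estimated at 50%, in a range from 25% to 80%.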

Compound 4, largest response reached (Emax), in percent of the reference or control that the assay uses: 53%
The estimate for compound 4 lay 3 percentage points below the measured number; the measured number falls inside the stated range.
By their numbers in this assay, from the lowest: compound 2; then compounds 4 and 3 (each within the scatter of the next); then compound 1.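

Exchanging cyclobutyl for 2-(methoxymethyl)-2-methylpropyl on the amine nitrogen in a ring gives, in this assay, a number 6 percentage points lower from compound 3 to compound 4 (within the scatter), the first comparison among these compounds that isolates this position. The four-membered carbon ring leaves and an open chain with one hydrogen-bond acceptor enters, yet the largest response of the pair cannot be told apart, so at this position and on this ring system, the agonist response tolerates this exchange of a compact ring for a larger, ring-free group carrying an oxygen. No measurement offered here explains why the two compounds read alike.

On these data alone, the pair speaks for only these two groups on a single ring system, so it remains open whether the same exchange would hold on the ring systems of compound 1 or compound 2. It also leaves open how the response in this assay would read with a simple unbranched butyl chain, a chain ending in a hydroxyl group or a carboxylic acid on the same nitrogen, which would show whether the methoxy oxygen or the branching contributes anything.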